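Taking one methoxy off the dimethoxyphenyl end

This account rests on a few compounds, and the source may have more. Where it says the series, first, only, none or still open, it means among the compounds named here.

Compound 1 `COc1ccc(/C=C/C(=O)/C=C/c2ccc(OCc3cn(CCCCOc4cc(=O)oc5ccccc45)nn3)c(OC)c2)cc1OC` gives 55%
Compound 2 `COc1ccc(/C=C/C(=O)/C=C/c2ccc(OCc3cn(CCCOc4cc(=O)oc5ccccc45)nn3)c(OC)c2)cc1OC` gives 67%

In a functional assay on HCT-116 cells (Homo sapiens) for inhibition, read by sulforhodamine B assay, with a stated time of 48 h, tested at 50 uM (a higher number here means more inhibition of growth at the concentration tested, a lower number less inhibition of growth), compound 1 gives 55% and so stands lowest of the two measured compounds. Compound 2 reaches 67% in the same test, and that gap lies beyond the usual scatter.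

The next molecule is compound 3 `COc1ccc(/C=C/C(=O)/C=C/c2ccc(OCc3cn(CCCCOc4cc(=O)oc5ccccc45)nn3)c(OC)c2)cc1`. It differs from compound 1 by one change (hydrogen in place of methoxy on an aromatic carbon): hydrogen in place of methoxy on an aromatic carbon, so that 3,4-dimethoxyphenyl becomes 4-methoxyphenyl. Among the compounds with values here, no measured pair of compounds shows this change, so the data give no direct guide to its effect in this assay. All else stays as in compound 1, so the expectation starts from its 55% and foresees no step beyond the scatter, with no firm direction. The estimated step is a number 2 percentage points lower from compound 1 to compound 3 (within the scatter) and is expected to stay within the usual scatter. Compound 3 is estimated at 53% within an expected range of 38% to 68% for this read-out.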

Compound 3, percent growth inhibition at one concentration: 40%
For compound 3 the middle estimate is 13 percentage points above the measured one; the measured number falls inside the stated range.
By their numbers in this assay, from the lowest: compound 3; then compound 1; then compound 2.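

In this assay, replacing the methoxy group with hydrogen, which turns 3,4-dimethoxyphenyl into 4-methoxyphenyl, gives a step of a number 15 percentage points lower from compound 1 to compound 3 (beyond the scatter). This place on the ring, ortho to a methoxy group and meta to a large group, therefore matters to growth inhibition at the concentration tested. Losing just two heavy atoms there changes the result by more than the usual scatter. Within the data shown here, compound 1 and compound 2 differ only in the chain, so they gave no reading on this end of the molecule, and this is the first sign that the dimethoxyphenyl end also affects the result. The compounds shown offer no measurement that explains why the loss occurs.

Hydrogen and methoxy are the only two groups compared at this place, so it remains open whether a hydroxy group, a chlorine atom or a longer ethoxy group would keep the activity of compound 1 or fall further. On these data alone, it is also open whether the same change would cost as much on compound 2, with its different chain.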